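A few compounds are considered here, and "the series" means these few. Any claim that something is new, unique, unknown or untested is made for them only; others in the source may bear on it.

Measured compounds in an assay on isolated protein for displacement of a labelled ligand from Bile acid receptor (Homo sapiens), read by scintillation proximity assay and radioligand binding; a higher number here means a weaker inhibitor, a lower number a stronger inhibitor:
- compound 1, `COc1ccccc1-c1noc(C(C)C)c1COc1ccc(/C=C/c2cccc(C(=O)O)c2)c(Cl)c1`, gives 250 nM
- compound 2, `Cc1cc(OCc2c(-c3[nH]c(=O)ccc3Cl)noc2C(C)C)ccc1-c1ccc2c(C(=O)O)cn(C)c2c1`, gives 4130 nM

Compound 2 stands at the higher of the two numbers in this assay. Its nearest neighbour is compound 1, whose number is lower by a margin that lies beyond the usual scatter, so compound 2 is the weaker of the pair as measured. Going by the values given here, no pair of compounds differing in a single place has been measured, so no single step can be read off.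

Compound 3, `Cc1cc(OCc2c(-c3ccn(C)c(=O)c3Cl)noc2C(C)C)ccc1-c1ccc2c(C(=O)O)cn(C)c2c1`, differs from compound 2 as follows: a group of 9 heavy atoms (6 carbon, 1 nitrogen, 1 oxygen, 1 chlorine; one six-membered aromatic ring with 1 hetero atom) in place of a group of 8 heavy atoms (5 carbon, 1 nitrogen, 1 oxygen, 1 chlorine; one six-membered aromatic ring with 1 hetero atom), on an aromatic carbon. The leaving group carries one hydrogen-bond donor and one acceptor; the entering group carries no donor and two acceptors, and is larger by one carbon. Among the compounds with values here, nothing among the measured compounds shows how this assay responds to such a change, so the step is expected to be small, possibly within the scatter, with a slight lean toward a lower number. Compound 3 is therefore estimated at 3000 nM, in a range of 1000 nM to 10000 nM, which amounts to an expected step of a 1.4-fold lower number from compound 2 to compound 3 (0.14 log units; within the scatter).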

Compound 3, half-maximal inhibitory concentration: 1720 nM
The estimate for compound 3 lay 1.7-fold (0.24 log units) above the measured number, and the stated range covers the measured number.
By their numbers in this assay, from the lowest: compound 1; then compound 3; then compound 2.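

In this assay, the exchange on the aromatic carbon next to the ring nitrogen of the five-membered aromatic ring gives the first single-place step among these compounds: a 2.4-fold lower number from compound 2 to compound 3 (0.38 log units; beyond the scatter), a modest step beyond the scatter. This shows that the position responds to a swap between two groups that each hold a six-membered aromatic ring with 1 hetero atom, where the entering group is larger by one carbon and has 0 hydrogen-bond donors in place of 1 hydrogen-bond donor. Nothing available accounts for the size or direction of this step.

Going by these compounds alone, compound 1 differs from compound 2 and compound 3 in more than one place, so no step to it can be read. As far as these compounds go, it remains open how this position would respond to a plain phenyl ring or an unsubstituted pyridine ring in the same place.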